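The compounds below may be only part of what the source reports. "The series", "measured", "known", "first", "only" and "open" are said of these compounds alone.

Compound 1 `COc1cc(/C=C/C(=O)c2cc3cc(O)ccc3oc2=O)cc(OC)c1OC` and compound 2 `COc1cccc(/C=C/C(=O)c2cc3ccc(O)cc3oc2=O)c1OC` share a core and differ only in where the hydroxy sits. In a functional assay on MOLT-4 cells (Homo sapiens) for cytotoxicity, read by MTT assay, with a stated time of 72 h (on this read-out higher numbers stand for weaker inhibition and lower numbers for stronger inhibition), compound 1 gives 3900 nM, and compound 2 gives 7000 nM. Compound 2 stands at one end of these two numbers, yet its gap to compound 1 lies within the usual scatter, so the two are not told apart. Compound 3 `COc1cccc(COc2ccc3cc(C(=O)/C=C/c4cccc(OC)c4OC)c(=O)oc3c2)c1` follows from compound 2 by 3-methoxybenzyl in place of hydrogen on an oxygen on an aromatic ring. Among the measured compounds shown here, no measured pair shows such a change, so the step is expected to stay small, in either direction or none beyond the scatter, with a 1.4-fold lower number from compound 2 to compound 3 (0.15 log units; within the scatter) as the estimate. Compound 3 is therefore expected to give 5000 nM, within 1500 nM to 15000 nM.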

Compound 3, half-maximal inhibitory concentration: 22800 nM
Compound 3: the middle estimate sits 4.6-fold (0.66 log units) below what was measured, and the stated range ends below it.
By their numbers in this assay, from the lowest: compounds 1 and 2 (each within the scatter of the next); then compound 3.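

In this assay, putting 3-methoxybenzyl in place of hydrogen on this oxygen on an aromatic ring gives a 3.3-fold higher number from compound 2 to compound 3 (0.51 log units; beyond the scatter), so the number does respond to what sits on this oxygen. Compounds 1 and 2, which differ in where the hydroxy sits, could not show this, since they are not told apart. No evidence here bears on why the number rises.

As far as these compounds go, whether a methyl or a chain ending in an amine on the same oxygen would stay near compound 2 remains open. So does whether the 3-methoxybenzyl change would give a similar step on compound 1.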